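A few compounds are considered here, and "the series" means these few. Any claim that something is new, unique, unknown or untested is made for them only; others in the source may bear on it.

Compound 1, `CCc1ccc(NC(=O)N[C@H](C)c2ccccc2)cc1`, is the starting point of this account. In an ADME assay on the whole organism with Oryza sativa as the target, tested at 0.1 uM (on this read-out lower numbers stand for a stronger effect and higher numbers for a weaker effect at the one concentration tested), compound 1 gives 95%. Compound 2, `CCc1ccc(NC(=O)N[C@@H](C)c2ccccc2)cc1`, gives 99% in this assay, and the step of a number 4 percentage points higher from compound 1 to compound 2 (within the scatter) is tied to the fact that compounds 1 and 2 differ only in the configuration as drawn. Compound 3, `C[C@H](NC(=O)Nc1cccc(I)c1)c1ccccc1`, gives 98% in this assay, so compound 1 sits within the scatter of both other compounds on the numbers shown.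

Compound 4, `C[C@@H](NC(=O)Nc1ccc(I)cc1)c1ccccc1`, is not yet measured. It differs from compound 1 by iodo in place of ethyl on an aromatic carbon. Within the data shown here, the only measured step, from compound 1 to compound 2, concerns configuration and not a substituent, so it offers no direct guide to this change; compound 3, which also carries an iodo group, shows a value within the scatter of compound 1. On that basis compound 4 is expected to stay at a similar level, with no step beyond the scatter. The estimate for compound 4 in this assay is 96%, within the range 88% to 100%. The expected step is a number 1 percentage points higher from compound 1 to compound 4 (within the scatter).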

Compound 4, a percentage reported as activity, at one concentration (the size of the read-out at that concentration, not a potency): 100%
For compound 4 the middle estimate is 4 percentage points below the measured one; the measured number falls inside the stated range.
By their numbers in this assay, from the lowest: compounds 1, 3, 2 and 4 (each within the scatter of the next).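

In this assay, iodo in place of ethyl on an aromatic carbon, para to a large group, gives a number 5 percentage points higher from compound 1 to compound 4 (within the scatter). Among these compounds, this is the first direct reading of a substituent change at this position, and it shows that exchanging ethyl for a single iodine atom does not carry the read-out beyond the scatter. Nothing given here offers a reason for this step.

The compounds shown leave open how an amine, a carboxylic acid or a longer chain at this position would read in this assay. They also leave open whether any change to the shared core, rather than to this one substituent, would move the number beyond the scatter.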